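Methoxy to nitro in a growth-inhibiting series

The source may report more compounds than this note shows. Statements on the series, on what has been measured and on what is new or still open speak of the compounds shown alone.

Measured so far in a functional assay on HL-60 cells (Homo sapiens) for inhibition, read by CCK-8 assay, with a stated time of 48 h, tested at 20 uM; a higher number here means more inhibition of growth at the concentration tested, a lower number less inhibition of growth:
compound 1 `N#C/C(=C\c1ccccc1OS(=O)(=O)c1ccc([N+](=O)[O-])cc1)C(=O)Nc1nnc(-c2cccs2)s1` gives 23%
compound 2 `N#C/C(=C\c1ccccc1OS(=O)(=O)c1ccc([N+](=O)[O-])cc1)C(=O)Nc1nnc(Cc2cccc(F)c2)s1` gives 18%
compound 3 `COc1ccc(S(=O)(=O)Oc2ccccc2/C=C(\C#N)C(=O)Nc2nnc(Cc3ccc(C)cc3)s2)cc1` gives 100%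

Compound 3 stands highest of the three, beyond the scatter from both others. Compound 4 `Cc1ccc(Cc2nnc(NC(=O)/C(C#N)=C/c3ccccc3OS(=O)(=O)c3ccc([N+](=O)[O-])cc3)s2)cc1` departs from compound 3 in one place, (nitro in place of methoxy on an aromatic carbon), with nitro in place of methoxy on an aromatic carbon. For the measured compounds named here, no measured step isolates this change. Going by the values given here, the only step, a number 5 percentage points lower from compound 1 to compound 2 (within the scatter), lies within the scatter and falls elsewhere in the structure. Still, the 4-nitrophenyl group is carried by compound 1 at 23% and by compound 2 at 18%, though both also differ from compound 3 elsewhere. The expected change is a number 65 percentage points lower from compound 3 to compound 4 (beyond the scatter) and so beyond the scatter, with wide uncertainty. Compound 4 is estimated at 35% with 12% to 90% as the expected range.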

Compound 4, percent growth inhibition at one concentration: 17%
For compound 4 the middle estimate is 18 percentage points above the measured one; low and high end bracket the measured number.
By their numbers in this assay, from the lowest: compounds 4, 2 and 1 (each within the scatter of the next); then compound 3.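

For the compounds shown here, with the 4-methylbenzyl group held fixed, the change from 4-methoxyphenyl to 4-nitrophenyl stands alone for the first time, and in this assay it gives a number 83 percentage points lower from compound 3 to compound 4 (beyond the scatter) as a large step. With the nitro group in place, exchanging the other substituent changes little: a number 1 percentage points lower from compound 2 to compound 4 (within the scatter) and a number 6 percentage points lower from compound 1 to compound 4 (within the scatter) both stay within the scatter. No measurement here accounts for the large step.

Going by these compounds, whether an amine or a hydroxyl at this place would match methoxy or nitro remains open. So does whether methoxy holds its effect alongside thiophen-2-yl or 3-fluorobenzyl.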